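The source may report more compounds than this note shows. Statements on the series, on what has been measured and on what is new or still open speak of the compounds shown alone.

Working notes on the series. Three analogues of one shared core differ only in the group on a nitrogen on an aromatic ring. Compound 1 `CCCC(=O)Nc1ncc(-c2cccc(Cl)c2)c(-c2ccccc2)n1` carries propylcarbonyl there, compound 2 `CC(C)CCNc1ncc(-c2cccc(Cl)c2)c(-c2ccccc2)n1` isopentyl, and compound 3 `Clc1cccc(-c2cnc(NC3CCCCC3)nc2-c2ccccc2)c1` cyclohexyl. In an assay on CHO cells for displacement of a labelled ligand from adenosine receptor A1 (Homo sapiens), read by scintillation counting, with a stated time of 1 h, tested at 1 uM (a higher number here means more inhibition at the concentration tested (going by the name of the read-out), a lower number less inhibition), compound 1 reaches > 80%, which is a limit of the assay and not a number (the limit of > 80% in this assay, at which 1 of the 3 values shown sits). Compound 2 gives 39% in this assay. Compound 3 gives 58% in this assay, the higher of the two plain numbers, with compound 2 as its nearest neighbour.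

The measured steps read: a number at least 41 percentage points lower from compound 1 to compound 2 (beyond the scatter); a number at least 22 percentage points lower from compound 1 to compound 3 (beyond the scatter); a number 19 percentage points higher from compound 2 to compound 3 (beyond the scatter). Both moves away from propylcarbonyl cost inhibition, while the exchange of one saturated hydrocarbon group for another moved the number only modestly.

Compound 4 `Clc1cccc(-c2cnc(NCc3ccccc3)nc2-c2ccccc2)c1` is not yet measured. It differs from compound 3 as follows: benzyl in place of cyclohexyl on a nitrogen on an aromatic ring. Among the measured compounds shown here, the only step that bears on it is a number 19 percentage points higher from compound 2 to compound 3 (beyond the scatter), since it alone compares two hydrocarbon groups on that nitrogen; no measured pair sets an aromatic ring against a saturated one. A step of no more than modest size in either direction is therefore expected in this assay. Compound 4 is expected to give 52%, in the range 28% to 78%. The expected step is then a number 6 percentage points lower from compound 3 to compound 4 (within the scatter).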

Compound 4, a percentage reported as inhibition, at one concentration (the size of the read-out at that concentration, not a potency): 16%
The estimate for compound 4 lay 36 percentage points above the measured number, and the stated range ends above it.
By their numbers in this assay, from the lowest: compound 4; then compound 2; then compound 3. At a limit, above all of these: compound 1.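

In this assay the position on a nitrogen on an aromatic ring does not treat all hydrocarbon groups alike: benzyl in place of cyclohexyl gives a number 42 percentage points lower from compound 3 to compound 4 (beyond the scatter) and so brings a large step, where the earlier exchange of one saturated group for another gave only a number 19 percentage points higher from compound 2 to compound 3 (beyond the scatter). Benzyl also falls short of the open-chain group, with a number 23 percentage points lower from compound 2 to compound 4 (beyond the scatter) as the printed step, so compound 4 sits lowest of the three compounds with plain numbers and the low value is not confined to the comparison with cyclohexyl. Against propylcarbonyl the change reads a number at least 64 percentage points lower from compound 1 to compound 4 (beyond the scatter) and the widest step in the set starts from the value of compound 1, which is a limit of the assay and not a number: the limit of > 80% in this assay, at which 1 of the 4 values shown sits.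

The compounds shown do not say whether the loss with benzyl belongs to the aromatic ring itself or to its distance from the nitrogen, a question that phenyl or 2-phenylethyl on the same nitrogen would address. They also leave open whether the high reading of compound 1 extends to other acyl groups such as acetyl or benzoyl, and they give no reason for any of these steps.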